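The compounds below may be only part of what the source reports. "The series", "measured", "known", "first", "only" and "open" are said of these compounds alone.

Of the compounds shown here, two sharing one core have been measured in a functional assay on the whole organism for inhibition, with Mus musculus as the target; on this read-out lower numbers stand for an effect already at smaller amounts and higher numbers for an effect only at larger amounts of compound. Compound 1 (`CCOC(=O)Nc1cccc2c1CN(C)CC2c1ccccc1`) gives about 4 mg/kg, while compound 2 (`CN1Cc2c(NC(=O)OCc3ccccc3)cccc2C(c2ccccc2)C1`) gives 16 mg/kg, the higher of the two numbers. Compound 3 (`CC(C)NCCC(=O)Nc1cccc2c1CN(C)CC2c1ccccc1`) keeps the core but carries 2-(isopropylamino)ethyl in place of benzyloxy on a carbonyl carbon. Among the measured compounds shown here, only one measured step bears on this part of the molecule, a 4.0-fold higher number from compound 1 to compound 2 (0.60 log units; beyond the scatter), where phenyl replaces methyl at the end of the group on the carbonyl carbon. For the measured compounds named here, that step is modest and offers only indirect guidance, since no measured compound carries an amino chain. Going by the values given here, compound 3 does lose the phenyl-bearing benzyloxy, and the one comparison available, a 4.0-fold higher number from compound 1 to compound 2 (0.60 log units; beyond the scatter), links that phenyl to the higher number. A modest move towards a lower number is therefore expected, though it may not clear the usual scatter. The expected change is a 2.0-fold lower number from compound 2 to compound 3 (0.30 log units; within the scatter). Compound 3 is estimated at 8 mg/kg, with an expected range from 2 mg/kg to 30 mg/kg.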

Compound 3, dose for half-maximal effect: about 125 mg/kg
Compound 3: middle estimate off by 16-fold (1.19 log units), on the low side; the measured number lies above the stated range.
By their numbers in this assay, from the lowest: compound 1; then compound 2; then compound 3.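

In this assay, the group on the carbonyl carbon turns out to matter more than the earlier pair could show: 2-(isopropylamino)ethyl brings a 7.8-fold higher number from compound 2 to compound 3 (0.89 log units; beyond the scatter) and a 31-fold higher number from compound 1 to compound 3 (1.49 log units; beyond the scatter), both beyond the usual scatter. The earlier step compared only benzyloxy and ethoxy, two groups attached through oxygen, and it tied the phenyl of benzyloxy to the higher number; compound 3 has no such phenyl in this group yet stands above both, so losing that phenyl does not by itself bring a lower number once the amino chain enters. No measurement available here accounts for the size of this rise.

Compound 3 changes the atom bound to the carbonyl carbon, adds a nitrogen and alters the chain all at once, so the compounds shown cannot say which of these changes goes with the higher number. A plain pentyl chain on the carbonyl carbon would test the chain without its amine, while a 2-(isopropylamino)ethoxy group would test the amine with the oxygen kept in place.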